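A few compounds are considered here, and "the series" means these few. Any claim that something is new, unique, unknown or untested is made for them only; others in the source may bear on it.

Compound 1 `COc1cc(O)c(C=O)c2c1[C@H](O)C[C@@H](c1ccccc1)O2` — 147000 nM
Compound 2 `COc1cc(O)c(C=O)c2c1[C@H](OC)C[C@@H](c1ccccc1)O2` — "not active" (no number reported)

Among the measured compounds shown here, in a functional assay on A549 cells (Homo sapiens) for cytotoxicity, read by MTT assay (on this read-out higher numbers stand for weaker inhibition and lower numbers for stronger inhibition), compound 1 gives 147000 nM, the only number in this set, since compound 2 was reported as "not active" (no number reported), without a number. Compound 3 `COc1c(C)c(O)c(C=O)c2c1[C@H](O)C[C@@H](c1ccccc1)O2` has not yet been measured. It differs from compound 1 by one small change: methyl in place of hydrogen on an aromatic carbon. With nothing else in hand to compare, this change is expected to move the result little, if at all, beyond the usual scatter. The expected step of a 1.1-fold lower number from compound 1 to compound 3 (0.05 log units; within the scatter) is small and in no firm direction. Compound 3 is therefore estimated at 130000 nM, within a range from 45000 nM to 400000 nM.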

Compound 3, half-maximal inhibitory concentration: "not active" (no number reported)
Nothing numeric was reported for compound 3; no gap can be computed for the estimate.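

Among the compounds shown here, compound 3 was reported as not active, without a number, so no step from compound 1 can be read in this assay. How far the added methyl shifts inhibition stays open, and no supporting data explain the result.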